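The source may report more compounds than this note shows. Statements on the series, on what has been measured and on what is new or still open speak of the compounds shown alone.

Compound 1 `CCC(C)(O)CC(=O)O[C@H](CC=C(C)C)C1=CC(=O)c2c(O)ccc(O)c2C1=O` gives 16000 nM in a functional assay on DU-145 cells (Homo sapiens) for cytotoxicity, read by MTT assay; a lower number here means a stronger inhibitor, a higher number a weaker inhibitor; compound 2 `CC[C@@](C)(O)CC(=O)O[C@H](CC=C(C)C)C1=CC(=O)c2c(O)ccc(O)c2C1=O` gives 12700 nM; compound 3 `CC(C)=CC[C@@H](OC(=O)C1CCCO1)C1=CC(=O)c2c(O)ccc(O)c2C1=O` gives 10500 nM.

In this assay compound 2 stands second highest of the three numbers, its nearest neighbour at a 1.2-fold lower number from compound 2 to compound 3 (0.08 log units; within the scatter) and its furthest at a 1.3-fold lower number from compound 1 to compound 2 (0.10 log units; within the scatter). All three values sit within the scatter of one another.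

Compound 4 `CCCC(O)CC(=O)O[C@H](CC=C(C)C)C1=CC(=O)c2c(O)ccc(O)c2C1=O` is not yet measured. It differs from compound 2 by 1-hydroxybutyl in place of 1-hydroxy-1-methylpropyl on a saturated chain carbon bound to a carbonyl carbon. Among the compounds with values here, no measured step makes this change: the step of a 1.3-fold lower number from compound 1 to compound 2 (0.10 log units; within the scatter) turns only on (the fact that one of compounds 1 and 2 is drawn with a defined configuration and the other without, at the place where they differ), while a 1.5-fold lower number from compound 1 to compound 3 (0.18 log units; within the scatter) and a 1.2-fold lower number from compound 2 to compound 3 (0.08 log units; within the scatter) replace the whole 2-hydroxy-2-methylbutyl with oxolan-2-yl and stay within the scatter. Such rearrangement of the acyl chain therefore gives no ground to expect a step beyond the scatter, estimated as a 1.0-fold higher number from compound 2 to compound 4 (0.01 log units; within the scatter). Compound 4 is estimated at 13000 nM, with a range of 6000 nM to 28000 nM.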

Compound 4, half-maximal inhibitory concentration: > 100000 nM
Compound 4: a limit, no number (the forecaster's own chance of this, stated with the estimate: 5%); middle value at least 7.6-fold (0.88 log units) from the limit.
By their numbers in this assay, from the lowest: compounds 3, 2 and 1 (each within the scatter of the next). At a limit, above all of these: compound 4.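

Compound 4 stands at a limit of the assay, not at a number: the limit of > 100000 nM in this assay, at which 1 of the 4 values shown sits.
With the same atoms joined differently on a saturated chain carbon bound to a carbonyl carbon, 1-hydroxybutyl in place of 1-hydroxy-1-methylpropyl gives an at least 7.8-fold higher number from compound 2 to compound 4 (0.89 log units; beyond the scatter) and an at least 6.2-fold higher number from compound 1 to compound 4 (0.79 log units; beyond the scatter). The change to 2-hydroxypentyl from oxolan-2-yl gives an at least 9.5-fold higher number from compound 3 to compound 4 (0.97 log units; beyond the scatter), so this acyl chain does not tolerate every rearrangement, although all steps among compounds 1, 2 and 3 stay within the scatter.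

As far as these compounds go, the true size of these steps stays open behind the limit. Also open, from the compounds shown here alone, is how 1-aminobutyl or a longer chain such as 1-hydroxyhexyl would read at this place.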